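Swapping the Ring on the Core Nitrogen

The source may hold more compounds than are shown below. What is called first, only, known or untested is meant among the compounds shown, and "the series" means these compounds.

Compound 1 `CC(C)c1onc(-c2c(Cl)cccc2Cl)c1COc1ccc(-c2nc3ccc(C(=O)O)cc3n2C2CCCCCC2)cc1` gives 921 nM in an assay on HEK-293T cells for antagonist activity at vitamin D3 receptor (Homo sapiens), read by a luciferase reporter, with a stated time of 24 h; a higher number here means a weaker inhibitor, a lower number a stronger inhibitor. Compound 2 `CC(=O)N1CCC(n2c(-c3ccc(OCc4c(-c5c(Cl)cccc5Cl)noc4C(C)C)cc3)nc3ccc(C(=O)O)cc32)CC1` gives in this assay only a limit, > 10000 nM, so no exact number is known for it. Among the measured compounds shown here, the one measured step, an at least 10-fold higher number from compound 1 to compound 2 (1.03 log units; beyond the scatter), was large, and compound 2 sits at the limit of > 10000 nM in this assay, at which 1 of the 2 values shown sits, which means the full size of that step is not known.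

Compound 3 `CC(C)c1onc(-c2c(Cl)cccc2Cl)c1COc1ccc(-c2nc3ccc(C(=O)O)cc3n2C2CCCCC2)cc1` differs from compound 2 by cyclohexyl in place of 1-acetylpiperidin-4-yl on an aromatic nitrogen. This undoes the kind of change that the measured step describes: a carbon-only ring again takes the place of the acetylated piperidine on the core nitrogen. For the measured compounds named here, the one measured step bears directly on it and was large, so a large drop in the number is expected here, as an at least 6.6-fold lower number from compound 2 to compound 3 (0.82 log units; beyond the scatter). Compound 3 is therefore estimated at 1500 nM, most likely between 500 nM and 5000 nM, in this assay.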

Compound 3, half-maximal inhibitory concentration: 1450 nM
For compound 3 the middle estimate is 1.0-fold (0.01 log units) above the measured one, and the stated range covers the measured number.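

In this assay, the two carbon-only rings on the aromatic nitrogen, cyclohexyl and cycloheptyl, cannot be told apart, with a 1.6-fold higher number from compound 1 to compound 3 (0.20 log units; within the scatter) between them. Ring size across this pair therefore matters far less than what the ring is made of: with the six-membered ring kept, replacing 1-acetylpiperidin-4-yl with cyclohexyl gives an at least 6.8-fold lower number from compound 2 to compound 3 (0.83 log units; beyond the scatter). As far as these compounds go, the full size of that step remains unknown, and compound 2 has only a limit: the limit of > 10000 nM in this assay, at which 1 of the 3 values shown sits.

The compounds shown do not separate the effect of the acetyl group from that of the ring nitrogen, a question that an unsubstituted piperidine with its free amine, or a tetrahydropyran ring, could address. From the compounds shown here alone, how a smaller ring such as cyclopentyl or an open butyl chain would behave at this position also remains open.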